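This account rests on a few compounds, and the source may have more. Where it says the series, first, only, none or still open, it means among the compounds named here.

Of the compounds shown here, three sharing one core have so far been measured in a functional assay on MT4 cells (Homo sapiens) for antiproliferative activity, read by MTT assay, with a stated time of 96 h; a lower number here means that less compound is needed, a higher number that more compound is needed for the effect. Compound 1 `CC(=O)/C(=C/c1c(-c2ccccc2)[nH]c2ccccc12)C(=O)c1ccccc1` gives 2000 nM in this assay, and compound 3 `CCOC(=O)/C(=C/c1c(-c2ccccc2)[nH]c2ccccc12)C(=O)c1ccc([N+](=O)[O-])cc1` gives 1500 nM. Compound 2 `N#C/C(=C\c1c(-c2ccccc2)[nH]c2ccccc12)C(N)=O` gives 6000 nM, the highest of the three numbers; compound 1 stands nearest and compound 3 furthest, each a lower number beyond the scatter. Compound 4 `COCCOC(=O)/C(C#N)=C/c1c(-c2ccccc2)[nH]c2ccccc12` has not yet been measured. It differs from compound 2 in one place: 2-methoxyethoxy in place of amino on a carbonyl carbon. For the measured compounds named here, no measured pair shows this change, so the expectation rests on compound 2 alone. The step is expected to read a 2.0-fold lower number from compound 2 to compound 4 (0.30 log units; within the scatter), a modest move toward a lower number, not clearly beyond the scatter. Compound 4 is accordingly estimated at 3000 nM, within 800 nM to 12000 nM.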

Compound 4, half-maximal effective concentration: 1200 nM
Compound 4: middle estimate off by 2.5-fold (0.40 log units), on the high side; measured number inside the range.
By their numbers in this assay, from the lowest: compounds 4, 3 and 1 (each within the scatter of the next); then compound 2.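

Swapping amino for 2-methoxyethoxy on this carbonyl carbon reads a 5.0-fold lower number from compound 2 to compound 4 (0.70 log units; beyond the scatter) in this assay. For the compounds shown here, this gives the first single-place step in the set and shows that the number responds to what this carbonyl carbon carries, which compounds 1 and 3, each differing from compound 2 in more than one place, could not show. No measurement shown accounts for this step.

From the compounds shown here alone, it remains open whether the step follows the loss of amino or the arrival of the chain. An ethoxy group, a methylamino group or a longer ether chain on the same carbonyl carbon would separate the two.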